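The source may report more compounds than this note shows. Statements on the series, on what has been measured and on what is new or still open speak of the compounds shown alone.

Measured so far in a functional assay on HT-29 cells (Homo sapiens) for inhibition, read by sulforhodamine B assay, with a stated time of 48 h; a lower number here means a stronger inhibitor of growth, a higher number a weaker inhibitor of growth:
compound 1 `O=C1C=CCC(/C=C/c2ccccc2)N1` gives 1200 uM.
compound 2 `O=C1C=CCC(/C=C/c2ccc(C(F)(F)F)cc2)N1` gives 139 uM.
compound 3 `COc1ccc(/C=C/C2CC=CC(=O)N2)cc1` gives only a limit of the assay, > 1090 uM.

Compound 3 therefore stands at the limit of > 1090 uM in this assay, at which 1 of the 3 values shown sits, and has no number of its own in this assay. Its step from compound 1 is a step that the limit leaves unreadable from compound 1 to compound 3. Against compound 2 the step is readable: an at least 7.8-fold higher number from compound 2 to compound 3 (0.89 log units; beyond the scatter). For comparison, an 8.6-fold lower number from compound 1 to compound 2 (0.94 log units; beyond the scatter), so the trifluoromethyl compound is the only one of the three with a clearly stronger growth inhibition.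

Compound 4 `COc1ccc(/C=C/C2CC=CC(=O)N2)c(OC)c1` differs from compound 3 by methoxy in place of hydrogen on an aromatic carbon. For the measured compounds named here, the steps that bear on it are the two that introduce a methoxy group: one unreadable from compound 1, one running to a weaker growth inhibition from compound 2. Nothing in these three compounds points to a second methoxy reversing that. The expectation for compound 4 in this assay is therefore a step that the limit leaves unreadable from compound 3 to compound 4, that is, none beyond the scatter, and most likely another limit. Compound 4 is estimated at 1300 uM, within 400 uM to 4000 uM.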

Compound 4, concentration for growth inhibition (reported as GI): > 964 uM
Compound 4 was reported as a limit (the forecaster's own chance of this, stated with the estimate: 70%); the middle value is on the limit's open side.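

For the compounds shown here, compound 3 and compound 4 are both reported only as limits in this assay, so no step between them can be read. The compounds shown leave open whether the added methoxy group on compound 4 changes growth inhibition at all, and in which direction.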